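The source may hold more compounds than are shown below. What is called first, only, known or untested is meant among the compounds shown, and "the series" means these compounds.

In an ADME assay on HepG2 2.2.15 cells (Homo sapiens) for cytotoxicity, read by MTT assay (a higher number here means that more compound is tolerated, a lower number that less compound is tolerated), compound 1 `C=C1CC[C@@H]2[C@](C)(COC(=O)/C=C/c3ccccc3)[C@H](O)CC[C@@]2(C)[C@@H]1/C=C/C1=CCOC1=O` gives 183000 nM, compound 2 `C=C1CC[C@@H]2[C@](C)(COC(=O)c3cccnc3)[C@H](O)CC[C@@]2(C)[C@@H]1/C=C/C1=CCOC1=O` gives 113000 nM and compound 3 `C=C1CC[C@@H]2[C@](C)(COC(=O)c3ccc(OC)nc3)[C@H](O)CC[C@@]2(C)[C@@H]1/C=C/C1=CCOC1=O` gives 1340000 nM, the highest of the three numbers. Compound 4 `C=C1CC[C@@H]2[C@](C)(COC(=O)c3ccco3)[C@H](O)CC[C@@]2(C)[C@@H]1/C=C/C1=CCOC1=O` carries furan-2-yl in place of 6-methoxypyridin-3-yl on a carbonyl carbon. Compound 3 stands apart from the other two: the swap that adds methoxy shows a 12-fold higher number from compound 2 to compound 3 (1.07 log units; beyond the scatter), and the comparison with the first ester shows a 7.3-fold higher number from compound 1 to compound 3 (0.86 log units; beyond the scatter), whereas the remaining pair shows a 1.6-fold lower number from compound 1 to compound 2 (0.21 log units; within the scatter). Compound 4 has no methoxy, so it is expected to fall back towards compound 1 and compound 2, a modest drop in this assay. The estimated change is a 6.7-fold lower number from compound 3 to compound 4 (0.83 log units; beyond the scatter). The expected value for compound 4 is 200000 nM, with an estimated range of 70000 nM to 700000 nM.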

Compound 4, half-maximal cytotoxic concentration: 92000 nM
For compound 4 the middle estimate is 2.2-fold (0.34 log units) above the measured one; the measured number falls inside the stated range.
By their numbers in this assay, from the lowest: compounds 4, 2 and 1 (each within the scatter of the next); then compound 3.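

Swapping in furan-2-yl in this assay gives a 15-fold lower number from compound 3 to compound 4 (1.16 log units; beyond the scatter), whereas the other two comparisons give a 1.2-fold lower number from compound 2 to compound 4 (0.09 log units; within the scatter) and a 2.0-fold lower number from compound 1 to compound 4 (0.30 log units; within the scatter). Pyridin-3-yl, 2-phenylethenyl and furan-2-yl on this carbonyl carbon therefore read alike, and among these four compounds only the 6-methoxypyridin-3-yl of compound 3 stands apart. Nothing shown explains why that group differs. Going by these compounds alone, only one methoxy-bearing ring appears, so it stays open whether methoxy on another ring would give the same rise, or whether an amine or a longer ethoxy chain in place of methoxy on the pyridine ring would.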